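The source may report more compounds than this note shows. Statements on the series, on what has been measured and on what is new or still open speak of the compounds shown alone.

Measured compounds in the series:

- compound 1 `CN1CCc2nc(C#Cc3ccccc3)sc2C1`; in an assay on HEK293 cells for negative allosteric modulation of metabotropic glutamate receptor 5 (Homo sapiens), read by FLIPR, with a stated time of 1 h (on this read-out higher numbers stand for weaker inhibition and lower numbers for stronger inhibition), compound 1 reaches only the limit of the assay, > 10000 nM.
- compound 2 `CCN1CCc2nc(C#Cc3ccccc3)sc2C1`; in this assay compound 2 gives 1200 nM.
- compound 3 `O=C(C1CCC1)N1CCc2nc(C#Cc3ccccc3)sc2C1`; in this assay compound 3 gives 370 nM.

Compound 3 holds the lowest number of the two values measured as numbers; its nearest neighbour is compound 2, at a 3.2-fold lower number from compound 2 to compound 3 (0.51 log units; beyond the scatter), which is beyond the scatter. The value of compound 1 is a limit and is read only as such (the limit of > 10000 nM in this assay, at which 1 of the 3 values shown sits).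

Compound 4 `CC1CCCC(C(=O)N2CCc3nc(C#Cc4ccccc4)sc3C2)C1` is not yet measured. It differs from compound 3 in one place: 3-methylcyclohexyl in place of cyclobutyl on a carbonyl carbon.

The steps measured so far all concern the group on the amine nitrogen in the ring. The step from hydrogen to methyl, an at least 8.3-fold lower number from compound 1 to compound 2 (0.92 log units; beyond the scatter), and the step to the cyclobutylcarbonyl, an at least 27-fold lower number from compound 1 to compound 3 (1.43 log units; beyond the scatter) and a 3.2-fold lower number from compound 2 to compound 3 (0.51 log units; beyond the scatter), both lowered the number. For the measured compounds named here, none of them compares one carbonyl-bound ring with another, so the change from cyclobutyl to 3-methylcyclohexyl has no direct precedent here. Since the amide is kept and only its ring is enlarged, the expectation for compound 4 is a number near that of compound 3, with a step of a 1.3-fold lower number from compound 3 to compound 4 (0.12 log units; within the scatter) that is estimated to stay within or close to the scatter. Compound 4 is therefore expected to give about 280 nM in this assay, in the range 80 nM to 1000 nM.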

Compound 4, half-maximal inhibitory concentration: > 10000 nM
Compound 4: only a limit was reported (the forecaster's own chance of this, stated with the estimate: 3%); at least 35-fold (1.55 log units) between middle value and limit.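

With the amide kept, the change of the ring on the carbonyl carbon gives an at least 27-fold higher number from compound 3 to compound 4 (1.43 log units; beyond the scatter), the only step shown that raises the number, and this step rests on a limit of the assay. An amide on the amine nitrogen in the ring therefore does not by itself keep the number low in this assay: the result also depends on what the carbonyl carbon carries, here cyclobutyl with 4 heavy atoms against 3-methylcyclohexyl with 7 heavy atoms, all of them carbon. Compound 4 reaches only a limit, which one other compound of the series shares: the limit of > 10000 nM in this assay, at which 2 of the 4 values shown sit.

Ring size and the added methyl change together in this single step, so the compounds shown do not separate their contributions, and how far compound 4 lies past the limit stays unknown. Cyclopentyl and unsubstituted cyclohexyl on the carbonyl carbon would be the groups to separate them, and the same position also leaves open how a ring carrying an amine or a carboxylic acid would read out.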